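Swapping the morpholine amide for a dimethylamide

This account rests on a few compounds, and the source may have more. Where it says the series, first, only, none or still open, it means among the compounds named here.

The shared core of compound 1 `O=C(c1cccc(C#Cc2ccccc2Nc2ncnc3ccc(Cl)nc23)c1)N1CCOCC1` carries an alkyne-linked phenyl bearing a morpholinyl carbonyl group. In an assay on isolated protein for inhibition of MAP kinase-interacting serine/threonine-protein kinase 2 (Homo sapiens), read by HTRF, in the presence of a further agent that is not named here (on this read-out higher numbers stand for weaker inhibition and lower numbers for stronger inhibition), compound 1 gives > 10000 nM, which is a limit of the assay rather than a number. Going by the values given here, compound 1 therefore sits at the limit of > 10000 nM in this assay, at which 1 of the 3 values shown sits, the one value of the three that is reported only as a limit. Two further compounds are measured alongside it. Compound 2 `N#Cc1ccc(Nc2ncnc3ccc(-c4ccc(C(=O)N5CCNCC5)cc4)nc23)cc1` gives 43 nM in this assay, a numerical value. Compound 3 `Cc1c(C(=O)N2CCOCC2)oc2ccc(Nc3ncnc4ccc(Cl)nc34)cc12` gives 1800 nM in this assay, also a numerical value. No pair of these compounds differs in a single place, so no measured step can be drawn between them.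

Compound 4 `CN(C)C(=O)c1cccc(C#Cc2ccccc2Nc2ncnc3ccc(Cl)nc23)c1` differs from compound 1 in one place: dimethylamino in place of morpholin-4-yl on a carbonyl carbon. No measured step exists for a change of this kind in this assay. Since compound 1 gives only the limit > 10000 nM, a small change at the amide nitrogen is expected to leave compound 4 without a measurable number, with a step from compound 1 to compound 4 estimated at a step that the limit leaves unreadable from compound 1 to compound 4, not beyond the scatter. Compound 4 is estimated at 15000 nM, expected to fall between 5000 nM and 50000 nM.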

Compound 4, half-maximal inhibitory concentration: > 10000 nM
Compound 4 was reported as a limit; the forecaster's own chance of this, stated with the estimate: 70%; the middle value is on the limit's open side.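

In this assay compound 4 gives > 10000 nM, a limit of the assay and not a number. Going by these compounds alone, compound 1 is likewise reported only as a limit, so no step from compound 1 to compound 4 can be read: the limit of > 10000 nM in this assay, at which 2 of the 4 values shown sit. The compounds shown leave open whether dimethylamino in place of morpholin-4-yl on a carbonyl carbon changes inhibition at all.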